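Adding a Trifluoromethyl Group to Compound 2

This account rests on a few compounds, and the source may have more. Where it says the series, first, only, none or still open, it means among the compounds named here.

Compound 1 `Cc1cccc(Oc2ccc(CC3SC(=O)NC3=O)cc2)n1` gives 2620 nM in a functional assay for agonist activity at Free fatty acid receptor 1 (Homo sapiens), read by FLIPR, in the presence of a further agent that is not named here; a higher number here means that more compound is needed for the effect, a lower number that less compound is needed.
Compound 2 `Cc1ccnc(Oc2ccc(CC3SC(=O)NC3=O)cc2)c1` gives 4280 nM.
Compound 3 `O=C1NC(=O)C(Cc2ccc(Oc3ccc(Cl)cc3)cc2)S1` gives 240 nM.

Compound 2 has the highest of the three numbers. Of the two steps from it, one is small, a 1.6-fold higher number from compound 1 to compound 2 (0.21 log units; within the scatter), and the other large, an 18-fold lower number from compound 2 to compound 3 (1.25 log units; beyond the scatter). Compound 4 `Cc1cc(Oc2ccc(CC3SC(=O)NC3=O)cc2)nc(C(F)(F)F)c1` differs from compound 2 by trifluoromethyl in place of hydrogen on an aromatic carbon. Among the compounds with values here, none of the measured steps adds a group to the ring that carries the methyl group: the small step moves the methyl group, and the large steps replace the whole ring, as in an 11-fold lower number from compound 1 to compound 3 (1.04 log units; beyond the scatter). The measured data therefore give no direct guide, and only a modest step is expected. For compound 4 the expected value is 2500 nM, between 800 nM and 8000 nM, meaning an expected 1.7-fold lower number from compound 2 to compound 4 (0.23 log units; within the scatter).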

Compound 4, half-maximal effective concentration: 688 nM
Estimate against measurement, compound 4: 3.6-fold (0.56 log units) above; the measured number lies below the stated range.
By their numbers in this assay, from the lowest: compound 3; then compound 4; then compounds 1 and 2 (each within the scatter of the next).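

In this assay, trifluoromethyl on an aromatic carbon next to the ring nitrogen gives a 6.2-fold lower number from compound 2 to compound 4 (0.79 log units; beyond the scatter), whereas moving the methyl group gave only a 1.6-fold higher number from compound 1 to compound 2 (0.21 log units; within the scatter). Within the data shown here, the earlier steps moved that methyl group or replaced the whole ring, so this is the first sign that keeping the ring and adding one group can take the number beyond the scatter. No measurement shown bears on the cause of this step. On these data alone, whether a nitrile or an amine at this place would also lower the number remains open, as does whether trifluoromethyl would do the same on compound 1.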